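The compounds below may be only part of what the source reports. "The series", "measured", "known", "first", "only" and "open" are said of these compounds alone.

In a functional assay on HCT-15 cells (Homo sapiens) for inhibition, read by sulforhodamine B assay, with a stated time of 48 h (a higher number here means a weaker inhibitor, a lower number a stronger inhibitor), the measured compounds are:
- compound 1 `CCCC[C@@]12O[C@]34CCCC=C3C(=O)O[C@@]43[C@H](CCC)[C@H]4C=C(C(=O)N1[C@H](C)c1ccccc1)[C@]32CC4` with 8500 nM
- compound 2 `CCCC[C@]12O[C@@]34CCCC=C3C(=O)O[C@]43[C@@H](CCC)[C@@H]4C=C(C(=O)N1[C@H](C)c1ccccc1)[C@@]32CC4` with 5400 nM

These two values lie within the scatter of each other, so compound 2 stands level with compound 1 and neither ranks ahead.

The next compound to be measured is compound 3 `CCCC[C@@]12O[C@]34CCCC=C3C(=O)O[C@@]43[C@H](CCC)[C@@H]4C=C(C(=O)N1[C@@H](C)c1ccccc1)[C@]32CC4` and it keeps the same atoms and bonds as compound 2. The change is the two compounds have the same atoms and bonds and differ only in configuration as drawn: 6 of 7 stereo elements differ; a stereocentre at a saturated ring carbon is drawn R in compound 2 and S in compound 3; a stereocentre at a saturated ring carbon is drawn S in compound 2 and R in compound 3; a stereocentre at a saturated ring carbon is drawn S in compound 2 and R in compound 3; a stereocentre at a saturated ring carbon is drawn S in compound 2 and R in compound 3 and nothing else, so no group leaves and none enters.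

For the measured compounds named here, only one measured step is of this kind. That step is a 1.6-fold lower number from compound 1 to compound 2 (0.20 log units; within the scatter) and it is also a change of configuration alone, as shown by the fact that compounds 1 and 2 differ only in the configuration as drawn in the drawn structures. From that single step, no change beyond the scatter is expected in this assay in either direction. One step is thin evidence, however, so the range is kept wide.

The expected move is a 1.2-fold higher number from compound 2 to compound 3 (0.08 log units; within the scatter) according to this estimate.

For compound 3 the estimated value is 6500 nM with 2600 nM as the lower end and 16000 nM as the upper end of the expected range.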

Compound 3, half-maximal inhibitory concentration: 7500 nM
Estimate against measurement, compound 3: 1.2-fold (0.06 log units) below; the measured number falls inside the stated range.
By their numbers in this assay, from the lowest: compounds 2, 3 and 1 (each within the scatter of the next).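

In this assay, the third arrangement of these same atoms and bonds stays level with the other two: a 1.4-fold higher number from compound 2 to compound 3 (0.14 log units; within the scatter), and a 1.1-fold lower number from compound 1 to compound 3 (0.05 log units; within the scatter). The second of these steps offers a closer comparison than any available before, with only 2 of 7 stereo elements differing, one at a saturated ring carbon and one at a saturated chain carbon, and its reading rests on a pair with no other structural difference: the fact that compounds 1 and 3 differ only in the configuration as drawn. Among these three compounds, then, neither the change at 6 of 7 stereo elements nor the change at 2 of 7 moves the number in this assay beyond the scatter.

The two stereo elements that separate compound 1 from compound 3 change together, so the contribution of each one alone cannot be read from these compounds. All three compounds also carry the same groups, which leaves open whether configuration would matter more in this assay on a core bearing an amine, a carboxylic acid or a longer chain.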